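A Larger Aryl Group on a Weakly Active Compound

A few compounds are considered here, and "the series" means these few. Any claim that something is new, unique, unknown or untested is made for them only; others in the source may bear on it.

In a functional assay on MCF7 cells (Homo sapiens) for cytotoxicity, read by MTT assay, with a stated time of 72 h (a lower number here means a stronger inhibitor, a higher number a weaker inhibitor), compound 1 (`Cn1ccc2c(Oc3ccc(NC(=O)c4cc5cccnc5n(-c5ccc(C(F)(F)F)c(Cl)c5)c4=O)cc3)ncnc21`) gives "not active" (no number reported) as its result, with no number. Among the compounds with values here, compound 2 (`Cn1ccc2c(Oc3ccc(NC(=O)c4cc5cccnc5n(-c5ccc(Cl)cc5)c4=O)cc3F)ncnc21`) gives 75000 nM and so holds the only number available. Compound 3 (`Cn1ccc2c(Oc3ccc(NC(=O)c4cc5cccnc5n(-c5ccc(C(F)(F)F)c(Cl)c5)c4=O)cc3F)ncnc21`) has 3-chloro-4-(trifluoromethyl)phenyl in place of 4-chlorophenyl on an aromatic nitrogen. Compound 1 already carries this entering group and gives "not active" (no number reported) as its result, so a slight weakening or no real change is expected in this assay here. The estimated move is a 1.2-fold higher number from compound 2 to compound 3 (0.08 log units; within the scatter) and remains small. For compound 3 the estimate is 90000 nM within a range from 35000 nM to 230000 nM overall.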

Compound 3, half-maximal inhibitory concentration: "not active" (no number reported)
Compound 3: no number reported; the estimate stays without a comparison.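

Compound 3 has no number in this assay, and the step from compound 2 to compound 3 cannot be read. The compounds shown leave open how 3-chloro-4-(trifluoromethyl)phenyl compares with 4-chlorophenyl, and no other data shown bear on this result.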